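Moving the Methoxy Group on a Chalcone Amide

The compounds below may be only part of what the source reports. "The series", "measured", "known", "first", "only" and "open" are said of these compounds alone.

Measured compounds:
- compound 1 `O=C(COc1ccc(/C=C/C(=O)c2ccc(F)cc2)cc1)Nc1ccc2c(c1)COC2=O`: 80.2%
- compound 2 `COc1ccc(/C=C/C(=O)c2ccc(OCC(=O)Nc3ccc4c(c3)COC4=O)cc2)cc1`: 63.7%

In an ADME assay on NIH3T3 cells (Mus musculus) for cytotoxicity, read by MTT assay, with a stated time of 48 h, tested at 100 uM (on this read-out higher numbers stand for a weaker effect at the one concentration tested and lower numbers for a stronger effect), compound 2 gives the lowest of the two numbers; compound 1 sits higher by a step beyond the scatter. Compound 3 `COc1cccc(/C=C/C(=O)c2ccc(OCC(=O)Nc3ccc4c(c3)COC4=O)cc2)c1` is not yet measured. It differs from compound 2 by 3-methoxyphenyl in place of 4-methoxyphenyl on a double-bonded chain carbon bound to a double-bonded chain carbon. For the measured compounds named here, with no measured step of this kind available, the expectation rests on compound 2 alone. The step from compound 2 to compound 3 is expected to be small, a number 1.3 percentage points higher from compound 2 to compound 3 (within the scatter), not beyond the scatter in either direction. Compound 3 is therefore estimated at 65%, within a range of 45% to 85%.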

Compound 3, a percentage reported as activity, at one concentration (the size of the read-out at that concentration, not a potency): 62.6%
The estimate for compound 3 lay 2.4 percentage points above the measured number, and the stated range covers the measured number.
By their numbers in this assay, from the lowest: compounds 3 and 2 (each within the scatter of the next); then compound 1.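

Putting 3-methoxyphenyl in place of 4-methoxyphenyl on a double-bonded chain carbon bound to a double-bonded chain carbon gives, in this assay, a number 1.1 percentage points lower from compound 2 to compound 3 (within the scatter). This is the first pair shown with the same atoms joined differently, and this read-out does not tell the two methoxyphenyl groups apart at this place. Nothing shown gives a reason for this result. Still open, from the compounds shown here alone, is whether a group other than methoxy on that phenyl ring, such as an amine or a carboxylic acid, would leave the number within the scatter too.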